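Moving the methoxy group on the anilino ring

The compounds below may be only part of what the source reports. "The series", "measured", "known", "first", "only" and "open" are said of these compounds alone.

Two measured compounds and one untested analogue share a core with a nitrile, an arylthiomethyl-triazole chain and an anilino group. Compound 1 `COc1ccccc1Nc1nc(SCc2cn(CC(=O)NC(=O)Nc3ccccn3)nn2)nc(-c2ccc(C(C)C)cc2)c1C#N` carries 2-methoxyphenyl on the anilino nitrogen together with a 4-isopropylphenyl ring. In a functional assay on MGC-803 cells (Homo sapiens) for inhibition, read by MTT assay, with a stated time of 72 h (on this read-out higher numbers stand for weaker inhibition and lower numbers for stronger inhibition), compound 1 gives only a limit of > 64000 nM. Among the compounds with values here, compound 2 `COc1ccc(Nc2nc(SCc3cn(CC(=O)NC(=O)Nc4ccccn4)nn3)nc(-c3ccc(C)cc3)c2C#N)cc1` carries 4-methoxyphenyl and a 4-methylphenyl ring, and in this assay compound 2 gives 1700 nM, the only numerical value available, so it is the sole reference point among the measured compounds (the limit of > 64000 nM in this assay, at which 1 of the 2 values shown sits). Compound 3 `COc1ccccc1Nc1nc(SCc2cn(CC(=O)NC(=O)Nc3ccccn3)nn2)nc(-c2ccc(C)cc2)c1C#N` differs from compound 2 in one place: 2-methoxyphenyl in place of 4-methoxyphenyl on a nitrogen on an aromatic ring. Compound 1 also carries the 2-methoxyphenyl group on that nitrogen. The step from compound 2 to compound 3 is therefore expected to go toward weaker inhibition, by an 8.8-fold higher number from compound 2 to compound 3 (0.95 log units; beyond the scatter), clearly beyond the usual scatter. Compound 3 is thus estimated at 15000 nM, with a likely span from 3000 nM to 64000 nM.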

Compound 3, half-maximal inhibitory concentration: 7960 nM
Compound 3: middle estimate off by 1.9-fold (0.28 log units), on the high side, within the range that was stated.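

Moving the methoxy group, with the atoms otherwise unchanged, gives a 4.7-fold higher number from compound 2 to compound 3 (0.67 log units; beyond the scatter) in this assay, so the place of this group on the ring alone separates the two compounds by more than the usual scatter, with 2-methoxyphenyl on the nitrogen reading weaker than 4-methoxyphenyl. The 2-methoxyphenyl group does not by itself account for the limit seen with compound 1, since methyl in place of isopropyl on an aromatic carbon, with that group kept, gives an at least 8.0-fold lower number from compound 1 to compound 3 (0.90 log units; beyond the scatter). This step is a bound and not an exact size, because compound 1 is known only as a limit: the limit of > 64000 nM in this assay, at which 1 of the 3 values shown sits.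

The compounds shown do not tell how 4-methoxyphenyl behaves together with the 4-isopropylphenyl ring, so it remains open whether the effects of the two changes simply add up. Also open, as far as these compounds go, is whether an ethoxy group, a hydroxyl group or an amine in place of the methoxy group would preserve the inhibition seen with compound 2, and nothing here explains why the two placements of the methoxy group differ.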